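This account rests on a few compounds, and the source may have more. Where it says the series, first, only, none or still open, it means among the compounds named here.

The series shares the core of compound 1, `CCOCCOc1cccc2ccc(N)nc12`. In an assay on cells with melanin-concentrating hormone receptor 1 (Homo sapiens) as the target, read by radioligand binding (a higher number here means a weaker inhibitor, a lower number a stronger inhibitor), compound 1 gives > 2000 nM, and this is a limit of the assay rather than a number, so compound 1 sits at the weak edge of what the measurement resolves. Compound 2, `Nc1ccc2cccc(OCCC3CCCCC3)c2n1`, differs in one place, and in this assay compound 2 gives 808 nM. That change, cyclohexyl in place of ethoxy on a saturated chain carbon, two bonds along the chain from an oxygen on an aromatic ring, brings an at least 2.4-fold lower number from compound 1 to compound 2 (0.39 log units; beyond the scatter); since one of the two values is the limit of > 2000 nM in this assay, at which 1 of the 2 values shown sits, only a lower bound of that step is known.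

Compound 3, `CC1CC1COc1cccc2ccc(N)nc12`, is still to be measured. It differs from compound 1 by 2-methylcyclopropyl in place of ethoxymethyl on a saturated chain carbon bound to an oxygen on an aromatic ring. Within the data shown here, the one measured step bears on it only loosely: it also trades an oxygen in the side chain for a carbon ring, but the entering ring here is three-membered rather than cyclohexyl. A step toward a lower number is therefore expected, an at least 1.3-fold lower number from compound 1 to compound 3 (0.12 log units; that floor lies within the scatter), though a more modest one. For compound 3 the estimate in this assay is 1500 nM, with a range from 600 nM to 4000 nM.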

Compound 3, half-maximal inhibitory concentration: 1640 nM
For compound 3 the middle estimate is 1.1-fold (0.04 log units) below the measured one; the range from low to high includes it.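

In this assay, this change at the saturated chain carbon bound to an oxygen on an aromatic ring swaps 4 heavy atoms for 4 heavy atoms, exchanging the open ethoxymethyl group, with its oxygen, for the all-carbon 2-methylcyclopropyl ring, and it brings an at least 1.2-fold lower number from compound 1 to compound 3 (0.08 log units; that floor lies within the scatter). Compound 3 thus has a measured number rather than a limit without any gain in heavy atoms, which the cyclohexyl step could not show. The true size of the step cannot be read, and it may lie within the scatter, because only a floor is known: the limit of > 2000 nM in this assay, at which 1 of the 3 values shown sits.

The compounds shown leave open whether the ring or the loss of the side-chain oxygen matters more, since neither change appears here alone; an open all-carbon chain such as butyl would bear on that. As far as these compounds go, it also remains open how this position would respond to an amine or a carboxylic acid at the end of the side chain, or to a longer chain ending in the same three-membered ring.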